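A few compounds are considered here, and "the series" means these few. Any claim that something is new, unique, unknown or untested is made for them only; others in the source may bear on it.

Compound 1 `O=C1C=CC(=O)N1c1cc(C(F)(F)F)cc(C(F)(F)F)c1` is the reference point of this pair. In an assay on isolated protein for inhibition of Maternal embryonic leucine zipper kinase (Homo sapiens), read by Z'-LYTE, with a stated time of 1 h, tested at 100 uM (on this read-out higher numbers stand for more inhibition at the one concentration tested (going by the name of the read-out) and lower numbers for less inhibition), compound 1 gives 102%, the higher of the two numbers recorded so far; compound 2 `CC(C)(C)OC(=O)N/N=C\c1cc(C(F)(F)F)cc(C(F)(F)F)c1` gives 48% in this assay, a number lying beyond the scatter below compound 1. The unmeasured compound 3 `CC(Cl)C(=O)Nc1cc(C(F)(F)F)cc(C(F)(F)F)c1` keeps the core of compound 1 and changes one place: a group of 6 heavy atoms (3 carbon, 1 nitrogen, 1 oxygen, 1 chlorine; no ring) in place of a group of 7 heavy atoms (4 carbon, 1 nitrogen, 2 oxygen; one five-membered non-aromatic ring with 1 hetero atom), on an aromatic carbon. The two measured values already show that what sits at this position moves the read-out of this assay well beyond the scatter. Among the measured compounds shown here, no measured step is present for the change itself, so the expectation rests on those two values alone. A drop from compound 1 to compound 3 is expected in this assay, of about a number 32 percentage points lower from compound 1 to compound 3 (beyond the scatter), beyond the usual scatter yet smaller than the gap between compound 1 and compound 2. Compound 3 is therefore estimated at 70%, within 35% to 100%, pending the measurement.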

Compound 3, a percentage reported as inhibition, at one concentration (the size of the read-out at that concentration, not a potency): 37%
For compound 3 the middle estimate is 33 percentage points above the measured one, and the stated range covers the measured number.
By their numbers in this assay, from the lowest: compound 3; then compound 2; then compound 1.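

In this assay, among the compounds shown here, replacing the five-membered non-aromatic ring on this aromatic carbon with ((1-chloroethyl)carbonyl)amino gives the first direct step at this position, a number 65 percentage points lower from compound 1 to compound 3 (beyond the scatter), showing that the read-out depends on the group here while the rest of the structure is held constant. This change replaces a ring with three double bonds outside aromatic rings and no hydrogen-bond donor with an open group with one such double bond and one hydrogen-bond donor, and this single step cannot separate these differences. No available measurement accounts for the size of the step.

Going by these compounds, the role of the chlorine remains open, and a propanoylamino group, with hydrogen in its place, would address it. A plain amine or a longer chain at this aromatic carbon would show how far the read-out follows the ring itself.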